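The source may report more compounds than this note shows. Statements on the series, on what has been measured and on what is new or still open speak of the compounds shown alone.

Series notes, adenosine receptor binding.

Of the compounds shown here, three of the shared core have been measured in an assay on Cerebral cortex for displacement of a labelled ligand from adenosine receptor A1 (Bos taurus); a higher number here means a weaker inhibitor, a lower number a stronger inhibitor. Compound 1 `CCNc1nc(-c2ccccc2)nc2c1nnn2Cc1ccccc1Cl` gives 463 nM. Compound 2 `Clc1ccccc1Cn1nnc2c(NC3CC3)nc(-c3ccccc3)nc21` gives 11 nM. Compound 3 `c1ccc(Cn2nnc3c(NC4CCC4)nc(-c4ccccc4)nc32)cc1` gives 5 nM, the lowest of the three numbers; the nearest is compound 2, the furthest compound 1.

Within the data shown here, the one single-point step measured so far concerns the amine substituent: a 42-fold lower number from compound 1 to compound 2 (1.62 log units; beyond the scatter). That step changes the amine and says nothing directly about the benzyl ring.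

Compound 4 `Clc1ccccc1Cn1nnc2c(NC3CCC3)nc(-c3ccccc3)nc21` differs from compound 3 in one place: chloro in place of hydrogen on an aromatic carbon, on an aromatic carbon of a six-membered aromatic ring of carbon only, ortho to a large group. Among the measured compounds shown here, no measured pair differs by this change alone. Compounds 2 and 3 differ in two places at once, the chloro and the ring size of the amine; compound 2 stands at 11 nM and compound 3 stands at 5 nM, and this cannot be split into a contribution from the chloro group alone.

For the measured compounds named here, with no direct precedent, the working expectation is a step of a 1.4-fold higher number from compound 3 to compound 4 (0.15 log units; within the scatter) in this assay, within or near the scatter, direction uncertain. For compound 4 the estimated value in this assay is therefore 7 nM, with a range from 2 nM to 25 nM.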

Compound 4, inhibition constant: 24 nM
Compound 4: the middle estimate sits 3.4-fold (0.54 log units) below what was measured; low and high end bracket the measured number.
By their numbers in this assay, from the lowest: compound 3; then compound 2; then compound 4; then compound 1.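

With the cyclobutyl amine held fixed, the change from benzyl to 2-chlorobenzyl gives a 4.8-fold higher number from compound 3 to compound 4 (0.68 log units; beyond the scatter) in this assay, so the chloro group, which compounds 2 and 3 could not isolate, now has a single-place reading: on this aromatic carbon it raises the number by a modest step beyond the scatter. With the 2-chlorobenzyl group held fixed, the amine steps differ in printed size: cyclobutyl in place of cyclopropyl gives a 2.2-fold higher number from compound 2 to compound 4 (0.34 log units; beyond the scatter) as a modest step, while cyclobutyl in place of ethyl gives a 19-fold lower number from compound 1 to compound 4 (1.29 log units; beyond the scatter) as a large one, so within these three compounds the ethyl amine stands apart from both ring amines. The measurements available offer no explanation for the size or direction of the chloro step.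

Going by these compounds, the chloro step is read on the cyclobutyl amine alone, so its size on the cyclopropyl or ethyl amine remains open. Also open, on these data alone, is how the benzyl ring responds to chloro at another place or to other groups, such as fluoro, methoxy or a carboxylic acid, and how the amine responds to a cyclopentyl ring.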